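Swapping the Aryl Group on a Scaffold Without Measured Potency

This account rests on a few compounds, and the source may have more. Where it says the series, first, only, none or still open, it means among the compounds named here.

Compound 1 (`COc1cc(/C=C/C(=O)c2sc(Nc3ccc(C)cc3)nc2C)cc(OC)c1OC`) was tested in a functional assay on NCI-H460 cells (Homo sapiens) for cytotoxicity, read by MTT assay; a higher number here means a weaker inhibitor, a lower number a stronger inhibitor. In this assay compound 1 gives only a limit, > 25000 nM, and not a number. Compound 2 (`Cc1ccccc1Nc1nc(C)c(C(=O)/C=C/c2ccc(Cl)cc2)s1`) was tested in the same way. In this assay compound 2 also returns only a limit, > 25000 nM. Both values shown so far thus rest at the same boundary, namely (the limit of > 25000 nM in this assay, at which 2 of the 2 values shown sit). Compound 3 (`COc1cc(/C=C/C(=O)c2sc(Nc3ccc(F)c(Cl)c3)nc2C)cc(OC)c1OC`) is not yet measured. It differs from compound 1 in one place: 3-chloro-4-fluorophenyl in place of 4-methylphenyl on a nitrogen on an aromatic ring. Going by the values given here, no step between two measured compounds is known here, so there is no yardstick for how such a change shifts the read-out. Because compound 1 shows only the limit > 25000 nM, the step that the limit leaves unreadable from compound 1 to compound 3 is expected to be none beyond the scatter. For compound 3 in this assay the estimate is 30000 nM, with a range from 8000 nM to 100000 nM, and a reading that is again only a limit is quite possible.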

Compound 3, half-maximal inhibitory concentration: 6310 nM
Beside the measured number, compound 3's estimate is 4.8-fold (0.68 log units) above it; measured number below the stated range.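

In this assay, putting 3-chloro-4-fluorophenyl in place of 4-methylphenyl on the nitrogen gives an at least 3.9-fold lower number from compound 1 to compound 3 (0.59 log units; beyond the scatter), the only step shown so far that can be read at all. Going by these compounds alone, compound 3 is also the only compound here that gives a number and not a limit, so this one change on the shared core is enough to bring the read-out into the measurable range. Only the minimum size of the step can be read, since the starting value is a limit and not a number: the limit of > 25000 nM in this assay, at which 2 of the 3 values shown sit.

The compounds shown cannot tell whether the chlorine, the fluorine or the two together account for the step, as both enter at once. They also leave open how this position would read with an amine or a carboxylic acid on the phenyl ring.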